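The source may hold more compounds than are shown below. What is called first, only, known or untested is meant among the compounds shown, and "the series" means these compounds.

In a physicochemical assay for solubility, in phosphate buffer, with a stated time of 2 h (a lower number here means a less soluble compound, a higher number a more soluble compound), compound 1 `CCCCc1ccc(-c2nc(C)c(/C(C)=N/NC(=N)N)s2)cc1` gives 62500 nM as its reading, compound 2 `Cc1nc(-c2ccc(-c3ccccc3)cc2)sc1-c1ccnc(NC(=N)N)n1` gives 2200 nM and compound 3 `Cc1nc(-c2ccc(-c3ccccc3)cc2)sc1-c1nnc(N2CCN(C)CC2)o1` gives 45000 nM on the same measurement. Compound 3 thus lies within the usual scatter of compound 1 and far beyond that scatter from compound 2. Compound 4 `Cc1nc(-c2ccc(-c3ccccc3)cc2)sc1-c1nnc(NC(=N)N)o1` differs from compound 3 at one place, where the change is a group of 4 heavy atoms (1 carbon, 3 nitrogen; no ring) in place of a group of 7 heavy atoms (5 carbon, 2 nitrogen; one six-membered non-aromatic ring with 2 hetero atoms), on an aromatic carbon and the 4-methylpiperazin-1-yl group is lost. For the measured compounds named here, no measured pair shows this exact change. The nearest guide is compound 2, which carries the entering group on a different core and gives 2200 nM in this assay as its reading. The expected change is an 11-fold lower number from compound 3 to compound 4 (1.05 log units; beyond the scatter) as a fall beyond the scatter. Compound 4 is estimated at 4000 nM with a range of 1000 nM to 16000 nM in this measurement.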

Compound 4, solubility: 128000 nM
For compound 4 the middle estimate is 32-fold (1.51 log units) below the measured one; the measured number lies above the stated range.
By their numbers in this assay, from the lowest: compound 2; then compounds 3 and 1 (each within the scatter of the next); then compound 4.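

In this assay, replacing the 4-methylpiperazin-1-yl group on this aromatic carbon with the smaller, ring-free group gives a 2.8-fold higher number from compound 3 to compound 4 (0.45 log units; beyond the scatter). This shows that, on this core, the six-membered ring is not needed at this position to keep the reading high, and that the reading can rise without it. No measurement offered here explains the rise. This single step leaves open how a simple amine or a carboxylic acid on the same carbon would read. It also cannot show whether the same swap would raise the number on another core.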